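The compounds below may be only part of what the source reports. "The series", "measured", "known", "first", "only" and "open" are said of these compounds alone.

Compound 1, `CC(C)(C)c1cc(NC(=O)[C@@H]2CCCCN2C(=O)c2ccc(Cl)cc2)no1`: 1.25 h
Compound 2, `CC(C)(C)c1cc(NC(=O)[C@@H]2CCCCN2C(=O)CC2CCOCC2)no1`: 1.83 h
Compound 3, `CC(C)(C)c1cc(NC(=O)[C@@H]2CCCCN2C(=O)N2CCOCC2)no1`: > 2 h

The three measured compounds share one core and differ only in the group on the carbonyl carbon that sits on the ring nitrogen. In an ADME assay (liver) for metabolic stability, with Liver microsome (Homo sapiens) as the target, read by LC-MS, using microsomes and NADPH, tested at 1 uM (on this read-out higher numbers stand for a longer-lived compound and lower numbers for a shorter-lived compound), compound 1 gives 1.25 h. Compound 2 gives 1.83 h in this assay, and the step of a 1.5-fold higher number from compound 1 to compound 2 (0.17 log units; within the scatter) stays within the scatter. For compound 3 this assay reports only a limit, > 2 h, so no number is known for it. This is the limit of > 2 h in this assay, at which 1 of the 3 values shown sits.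

Compound 4, `CC(=O)N1CCN(C(=O)N2CCCC[C@H]2C(=O)Nc2cc(C(C)(C)C)on2)CC1`, has not yet been measured. It differs from compound 3 in one place: 4-acetylpiperazin-1-yl in place of morpholin-4-yl on a carbonyl carbon. The measured steps that bear on this change are the two that also exchange the group on this carbonyl carbon, an at least 1.6-fold higher number from compound 1 to compound 3 (0.20 log units; that floor lies within the scatter) and an at least 1.0-fold higher number from compound 2 to compound 3 (0.03 log units; that floor lies within the scatter); neither rose beyond the scatter, and both end at the limit of the assay. Compound 4 is therefore expected to show no step beyond the scatter from compound 3, a step that the limit leaves unreadable from compound 3 to compound 4, in this assay. Compound 4 is estimated at 2.2 h, with a range from 1.2 h to 4 h, and this assay may well again report only a limit for it.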

Compound 4, half-life in the Liver microsome assay: > 2 h
Compound 4 ended at the assay's limit; the forecaster's own chance of this, stated with the estimate: 55%; the middle value lies beyond the limit too.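

In the Liver microsome assay, compound 4 gives > 2 h, which is a limit of the assay and not a number. In the Liver microsome assay, compound 4 joins compound 3 at the assay's limit, so the limit now holds for two groups on this carbonyl carbon, morpholin-4-yl and 4-acetylpiperazin-1-yl, and not for morpholin-4-yl alone: the limit of > 2 h in the Liver microsome assay, at which 2 of the 4 values shown sit.

Against the other two groups, the data give only floors, an at least 1.0-fold higher number from compound 2 to compound 4 (0.03 log units; that floor lies within the scatter) and an at least 1.6-fold higher number from compound 1 to compound 4 (0.20 log units; that floor lies within the scatter), so neither comparison shows a rise beyond the scatter, and the step between the two limits cannot be read. In a physicochemical assay for solubility, read by HPLC, at pH 6.8 (on this read-out lower numbers stand for lower solubility and higher numbers for higher solubility), compound 3 gives 45 ug/mL and compound 4 gives 62 ug/mL. In the physicochemical assay, the same exchange gives a 1.4-fold higher number from compound 3 to compound 4 (0.14 log units; within the scatter), so this read-out does not separate the two groups either.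

On these data alone, how far compound 3 and compound 4 lie past the limit stays open, and with it any order between them in the Liver microsome assay. Also open, as far as these compounds go, is whether a simple dimethylamino group or a piperidin-1-yl group on this carbonyl carbon, neither of which carries a second hetero atom in a ring, would reach the same limit.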